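The source may hold more compounds than are shown below. What is called first, only, known or untested is meant among the compounds shown, and "the series" means these compounds.

Working notes on the series.

Three compounds of the shared core have been run in a functional assay on CHO-K1 cells for antagonist activity at adenosine receptor A1 (Homo sapiens), read by a beta-galactosidase reporter and cAMP accumulation, with stated times of 15 min and 6 h; a lower number here means a stronger inhibitor, a higher number a weaker inhibitor. Compound 1 `Cc1ccc(-c2nc(N)c3cc(-c4ccccc4)sc3n2)o1` gives 520 nM. Compound 2 `N#Cc1ccc(-c2nc(N)c3cc(Cc4ccccc4)sc3n2)o1` gives 3160 nM. Compound 3 `CC(c1ccccc1)c1cc2c(N)nc(-c3cccc(C#N)c3)nc2s1` gives 1770 nM. Among the three numbers, compound 2 stands highest; its nearest neighbour is compound 3, and the gap to compound 3 is within the usual scatter, so no order can be read from that pair. The gap to compound 1 is the largest and lies beyond the scatter: compound 1 gives the lower number of the two.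

The next compound, compound 4 `Nc1nc(-c2cccc(Cl)n2)nc2sc(Cc3ccccc3)cc12`, is not yet measured in this assay. Going by the values given here, it differs from compound 2 in one place: 6-chloropyridin-2-yl in place of 5-cyanofuran-2-yl on an aromatic carbon No other pair in the set shares this change, so there is no measured step to lean on. Given that compound 2 gives 3160 nM and that compounds 1 and 3 carry different groups at this place as well as elsewhere, the expectation for compound 4 is a step of no more than modest size, most likely toward a somewhat lower number, as a 2.0-fold lower number from compound 2 to compound 4 (0.30 log units; within the scatter). Compound 4 is therefore estimated at 1600 nM in this assay, with a range from 400 nM to 6000 nM.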

Compound 4, inhibition constant: > 1000 nM
Compound 4: only a limit was reported; the forecaster's own chance of this, stated with the estimate: 5%; the middle value lies beyond the limit too.
By their numbers in this assay, from the lowest: compound 1; then compounds 3 and 2 (each within the scatter of the next).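

In this assay, going by these compounds alone, compound 4 gives > 1000 nM, which is a limit of the assay and not a number, so no step from compound 2 to compound 4 can be read. The compounds shown leave open whether 6-chloropyridin-2-yl in place of 5-cyanofuran-2-yl on an aromatic carbon changes the number, in which direction, and by how much.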